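The source may hold more compounds than are shown below. What is called first, only, known or untested is meant among the compounds shown, and "the series" means these compounds.

Compounds measured so far:
compound 1, `CC1=C(C(=O)CC(C)C)C(c2ccsc2)NC(=O)N1`, 37%
compound 2, `CCNC(=O)C1=C(C)NC(=O)NC1c1cccs1`, 1%

Both were tested in an assay on membranes from CHO cells for displacement of a labelled ligand from adenosine receptor A1 (Homo sapiens), read by scintillation counting, with a stated time of 60 min, tested at 1 uM; on this read-out lower numbers stand for less inhibition and higher numbers for more inhibition at the one concentration tested (going by the name of the read-out). Compound 2 gives the lower of the two numbers, and its gap to compound 1 is beyond the usual scatter; the two differ in more than one place, so only their values can be compared. Compound 3, `CCNC(=O)C1=C(C)NC(=O)NC1c1ccsc1`, has not yet been tested. It differs from compound 2 by a single rearrangement of the same atoms: thiophen-3-yl in place of thiophen-2-yl on a saturated ring carbon. Among the measured compounds shown here, no pair of measured compounds that differs in one place only is available to show what size of step this change brings. Compound 1 carries the same thiophen-3-yl group but a different side group, so it cannot settle the matter. A small rise in this assay, not clearly beyond the scatter, is expected for compound 3, a step of a number 7 percentage points higher from compound 2 to compound 3 (within the scatter). Compound 3 is estimated at 8%, within 0% to 25%.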

Compound 3, a percentage reported as inhibition, at one concentration (the size of the read-out at that concentration, not a potency): 3%
Beside the measured number, compound 3's estimate is 5 percentage points above it; low and high end bracket the measured number.
By their numbers in this assay, from the lowest: compounds 2 and 3 (each within the scatter of the next); then compound 1.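

In this assay, thiophen-3-yl in place of thiophen-2-yl on the saturated ring carbon gives a number 2 percentage points higher from compound 2 to compound 3 (within the scatter) and so, with the ethylcarbamoyl group present, this rearrangement of the same atoms makes no clear difference. Ethylamino in place of isobutyl on the carbonyl carbon gives a number 34 percentage points lower from compound 1 to compound 3 (beyond the scatter) and so, with thiophen-3-yl held constant, the side group makes a large difference where the ring attachment made none. The data offer no measured explanation for either step.

Among the compounds shown here, it remains open whether the thiophene attachment would matter with isobutyl on the carbonyl carbon, since the single comparison here has ethylamino there. It is also unknown how a phenyl ring on the saturated ring carbon, or a longer chain such as n-pentyl on the carbonyl carbon, would compare.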